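The source may report more compounds than this note shows. Statements on the series, on what has been measured and on what is new or still open speak of the compounds shown alone.

Measured compounds in a physicochemical assay, read by spectrophotometry, with a stated time of 25 min; on this read-out higher numbers stand for weaker inhibition and lower numbers for stronger inhibition:
- compound 1 `O=c1cc(-c2ccccc2)oc2cc(OCCCCNc3nc4ccccc4s3)cc(O)c12`: 26.5 ug/mL
- compound 2 `Cc1ccc2nc(NCCCCOc3cc(O)c4c(=O)cc(-c5ccccc5)oc4c3)sc2c1`: 28.1 ug/mL
- compound 3 `O=c1cc(-c2ccccc2)oc2cc(OCCCCNc3nc4ccc(Br)cc4s3)cc(O)c12`: 16.1 ug/mL

Compound 3 holds the lowest of the three numbers, yet it cannot be set apart from the others: the step of a 1.6-fold lower number from compound 1 to compound 3 (0.22 log units; within the scatter) and the step of a 1.7-fold lower number from compound 2 to compound 3 (0.24 log units; within the scatter) both stay within the scatter, as does the step of a 1.1-fold higher number from compound 1 to compound 2 (0.03 log units; within the scatter). Compound 4 `O=c1cc(-c2ccccc2)oc2cc(OCCCCNc3nc4ccc(I)cc4s3)cc(O)c12` has not yet been measured in this assay. It differs from compound 3 by one change: iodo in place of bromo on an aromatic carbon.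

Among the measured compounds shown here, no measured pair swaps one halogen for another, so the nearest guide is the move from hydrogen or methyl to bromo on the same ring, and both of those moves stayed within the scatter. A swap of bromo for iodo at the same carbon is therefore expected to give a number close to that of compound 3, with no step beyond the scatter; the expected step is a 1.2-fold lower number from compound 3 to compound 4 (0.06 log units; within the scatter). Compound 4 is estimated at 14 ug/mL, within a range from 7 ug/mL to 28 ug/mL.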

Compound 4, half-maximal inhibitory concentration: 25.4 ug/mL
For compound 4 the middle estimate is 1.8-fold (0.26 log units) below the measured one, within the range that was stated.
By their numbers in this assay, from the lowest: compounds 3, 4, 1 and 2 (each within the scatter of the next).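

In this assay the only halogen-for-halogen swap shown at this carbon gives a 1.6-fold higher number from compound 3 to compound 4 (0.20 log units; within the scatter) and so does not separate iodo from bromo. The other two steps to compound 4 read a 1.1-fold lower number from compound 2 to compound 4 (0.04 log units; within the scatter) and a 1.0-fold lower number from compound 1 to compound 4 (0.02 log units; within the scatter) and leave iodo level with methyl and hydrogen at the same carbon. Across hydrogen, methyl, bromo and iodo, then, no group at this position has taken the number beyond the scatter, and nothing available offers an explanation for these values.

On these data alone, whether an amine, a carboxylic acid or a nitrile at this carbon would give a step beyond the scatter stays open. So does the effect of a longer chain in place of the one shared by these compounds.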